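A few compounds are considered here, and "the series" means these few. Any claim that something is new, unique, unknown or untested is made for them only; others in the source may bear on it.

Working notes on the series, step from compound 3 to compound 4.

Compound 3 `C=C1C[C@]23C[C@@]1(O)CC[C@H]2c1ccc(O)c(C)c1[C@@H]3Cn1cc(-c2ccccc2)nn1` carries a plain phenyl on the triazole of the shared core. In a functional assay on A549 cells (Homo sapiens) for cytotoxicity, read by MTT assay, with a stated time of 4 days (on this read-out lower numbers stand for stronger inhibition and higher numbers for weaker inhibition), compound 3 gives > 20000 nM, which is a limit of the assay and not a number. Compound 1 `C=C1C[C@]23C[C@@]1(O)CC[C@H]2c1ccc(O)c(C)c1[C@@H]3Cn1cc(-c2ccc(C(F)(F)F)cc2)nn1`, the trifluoromethyl analogue, in this assay gives 10400 nM. Compound 2 `C=C1C[C@]23C[C@@]1(O)CC[C@H]2c1ccc(OS(=O)(=O)c2ccc(C)cc2)c(C)c1[C@@H]3Cn1cc(-c2ccc(F)cc2)nn1`, with the phenol as a tosylate and 4-fluorophenyl on the triazole, in this assay gives > 20000 nM, again a limit rather than a number.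

Compound 4 `C=C1C[C@]23C[C@@]1(O)CC[C@H]2c1ccc(O)c(C)c1[C@@H]3Cn1cc(-c2ccc(F)cc2)nn1` differs from compound 3 by fluoro in place of hydrogen on an aromatic carbon. Among the measured compounds shown here, the only measured step touching this aromatic position is an at least 1.9-fold higher number from compound 1 to compound 3 (0.28 log units; that floor lies within the scatter), and its floor lies within the scatter, so the substituent effect is not resolved; both compound 3 and compound 2 sit at the limit of > 20000 nM in this assay, at which 2 of the 3 values shown sit. Compound 3 therefore offers no reliable anchor, and a fluoro on the same aromatic carbon is expected to leave the value close to that limit, with some chance of a number in the region of compound 1.

Compound 4 is expected at 20000 nM, within 9000 nM to 40000 nM. The step this estimate means, a number no higher from compound 3 to compound 4 (the limit leaves the size open), is expected to stay within the scatter, with a limit again likely.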

Compound 4, half-maximal inhibitory concentration: > 20000 nM
Compound 4: only a limit was reported (the forecaster's own chance of this, stated with the estimate: 55%); the middle value sits exactly at the limit.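

In this assay, the change from phenyl to 4-fluorophenyl gives a second limit rather than a number, so fluoro in place of hydrogen on this aromatic carbon has no readable effect, and the steps from compound 3 to compound 4 and from compound 2 to compound 4 cannot be read, each joining two limits. Among the compounds shown here, the one readable new step at this position is an at least 1.9-fold higher number from compound 1 to compound 4 (0.28 log units; that floor lies within the scatter), so compound 4 is no better separated from trifluoromethyl-bearing compound 1 than compound 3 was. Compound 1 thus stays the only compound with an actual number, and the rest of the series gives no measured baseline for this position: the limit of > 20000 nM in this assay, at which 3 of the 4 values shown sit.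

Still open, from the compounds shown here alone, is whether any other group on this aromatic carbon, such as an amine or a carboxylic acid, would give a number clearly apart from that of compound 1. Also open, going by these compounds, is what the phenol oxygen contributes, which a longer chain or an acetyl group there could show only if the value came off the limit.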